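The compounds below may be only part of what the source reports. "The series", "measured", "known", "first", "only" and "open" are said of these compounds alone.

Working notes on the series.

In a functional assay on PC-9 cells (Homo sapiens) for inhibition, read by MTT assay, with a stated time of 48 h, tested at 10 uM (on this read-out higher numbers stand for more inhibition at the one concentration tested (going by the name of the read-out) and lower numbers for less inhibition), compound 3 `CCc1cccc(Nc2cc(NC(=O)Nc3cc(OC)cc(OC)c3)ncn2)c1` gives 82.1%, which is the second highest of the three numbers to hand. Compound 2 `COc1ccc(OC)c(Nc2cc(NC(=O)Nc3c(Cl)cccc3Cl)ncn2)c1` gives 95% in this assay, a number beyond the scatter above compound 3, and compound 1 `COc1ccc(Br)cc1Nc1cc(NC(=O)Nc2c(Cl)cccc2Cl)ncn1` gives 69%, beyond the scatter below it. Among the compounds with values here, the only measured step between neighbours is a number 26 percentage points higher from compound 1 to compound 2 (beyond the scatter); compound 1 carries a bromo where compound 2 carries a methoxy.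

Compound 4 `COc1cc(NC(=O)Nc2cc(Nc3ccc(OC)c(I)c3)ncn2)cc(OC)c1` is not yet measured in this assay. It differs from compound 3 by 3-iodo-4-methoxyphenyl in place of 3-ethylphenyl on a nitrogen on an aromatic ring. The step from compound 1 to compound 2 bears on this only loosely: it shows that, in this assay, an aniline carrying a halogen next to a methoxy sat well below an aniline carrying two methoxy groups, on a different urea partner. Within the data shown here, no measured step tests the removal of the 3-ethylphenyl itself. A modest decrease from compound 3 is therefore expected, and the estimated step is a number 10.1 percentage points lower from compound 3 to compound 4 (beyond the scatter). Compound 4 is expected to give about 72% in this assay, within a range of 50% to 90%.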

Compound 4, a percentage reported as inhibition, at one concentration (the size of the read-out at that concentration, not a potency): 47.1%
Estimate against measurement, compound 4: 24.9 percentage points above, and the stated range ends above it.
By their numbers in this assay, from the lowest: compound 4; then compound 1; then compound 3; then compound 2.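

In this assay, the aryl group on this nitrogen strongly affects the read-out even when the rest of compound 3 is unchanged: 3-iodo-4-methoxyphenyl in place of 3-ethylphenyl gives a number 35 percentage points lower from compound 3 to compound 4 (beyond the scatter). Alongside a number 26 percentage points higher from compound 1 to compound 2 (beyond the scatter), this is a second pair in which the aniline ring carrying a halogen gives the lower number, although the two pairs have different urea partners and make different changes, so this is no more than a tentative pattern. No measurement offered here explains the drop.

The compounds shown do not separate the contributions of the iodo group, the methoxy group and the absence of the ethyl group in this series. They also leave open how a longer chain in place of the ethyl group, or an amine on this ring, would read out.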